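A new group on the carbonyl of compound 1

The source may report more compounds than this note shows. Statements on the series, on what has been measured and on what is new or still open speak of the compounds shown alone.

compound 1 `CCN(CC)S(=O)(=O)c1ccc(S(=O)(=O)N2CCC[C@@H](C(=O)N3CCC(O)CC3)C2)cc1` gives 870 nM
compound 2 `O=C([C@@H]1CCCN(S(=O)(=O)c2ccc(S(=O)(=O)C3CC3)cc2)C1)N1CCC(F)(F)CC1` gives 26 nM
compound 3 `CN(C)S(=O)(=O)c1ccc(S(=O)(=O)N2CCC[C@@H](C(=O)N3CCC(F)(F)CC3)C2)cc1` gives 118 nM

In a functional assay on MIA PaCa-2 cells (Homo sapiens) for inhibition, read by MTT assay, with a stated time of 7 days (on this read-out higher numbers stand for weaker inhibition and lower numbers for stronger inhibition), compound 1 at 870 nM has the highest number of the three, so it inhibits most weakly. Compound 4 `CCN(CC)S(=O)(=O)c1ccc(S(=O)(=O)N2CCC[C@@H](C(=O)N[C@H]3CC[C@@H](OC)CC3)C2)cc1` keeps the core of compound 1 but carries (4-methoxycyclohexyl)amino in place of 4-hydroxypiperidin-1-yl on a carbonyl carbon. Going by the values given here, no measured step covers this swap. Among the compounds with values here, the only measured step is a 4.5-fold higher number from compound 2 to compound 3 (0.66 log units; beyond the scatter) and it concerns a sulfonyl sulfur instead. Compound 3 at 118 nM also differs from compound 1 on that carbonyl carbon, so much lower numbers occur with another group there, though its sulfonyl group differs too. A lower number is therefore expected, and the estimated move is a 4.4-fold lower number from compound 1 to compound 4 (0.64 log units; beyond the scatter) in this assay with wide uncertainty. For compound 4 the expected value is 200 nM within an estimated range of 45 nM to 850 nM for now.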

Compound 4, half-maximal inhibitory concentration: 960 nM
Beside the measured number, compound 4's estimate is 4.8-fold (0.68 log units) below it, outside the stated range (above it).
By their numbers in this assay, from the lowest: compound 2; then compound 3; then compounds 1 and 4 (each within the scatter of the next).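

In this assay, the change on the carbonyl carbon gives a 1.1-fold higher number from compound 1 to compound 4 (0.04 log units; within the scatter), so compound 1 and compound 4 cannot be told apart. On this core, then, the 4-hydroxypiperidin-1-yl group and the larger (4-methoxycyclohexyl)amino group, with its carbon-only ring, read alike, and this step alone does not show which feature of a group at this position matters. No available measurement offers a reason for this result. As far as these compounds go, compound 1 and compound 3 differ in two places, so the share of each place stays open. From the compounds shown here alone, how a morpholin-4-yl group on that carbonyl carbon would read also remains open.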